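This account rests on a few compounds, and the source may have more. Where it says the series, first, only, none or still open, it means among the compounds named here.

For the measured compounds named here, in an assay on cells for antagonist activity at transient receptor potential cation channel subfamily V member 1 (Homo sapiens), read by FLIPR and calcium flux, with a stated time of 6 min (on this read-out higher numbers stand for weaker inhibition and lower numbers for stronger inhibition), compound 3 `CC(C(=O)NCc1ccc(C(C)(C)C)nc1SCCCN1CCCC1)c1ccc(NS(C)(=O)=O)c(F)c1` gives 17.1 nM, the highest number among the three compounds measured so far and therefore the weakest inhibitor of the set. Compound 1 `CC(C(=O)NCc1ccc(C(C)(C)C)nc1N1CCCCCC1)c1ccc(NS(C)(=O)=O)c(F)c1` gives 0.9 nM, and compound 2 `CCC1CCN(c2nc(C(C)(C)C)ccc2CNC(=O)C(C)c2ccc(NS(C)(=O)=O)c(F)c2)CC1` gives 0.1 nM. The gaps are wide: a 19-fold higher number from compound 1 to compound 3 (1.28 log units; beyond the scatter), a 170-fold higher number from compound 2 to compound 3 (2.23 log units; beyond the scatter), and a 9.0-fold lower number from compound 1 to compound 2 (0.95 log units; beyond the scatter).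

Compound 4 `CCCCCc1nc(C(C)(C)C)ccc1CNC(=O)C(C)c1ccc(NS(C)(=O)=O)c(F)c1` differs from compound 3 in one place: pentyl in place of (3-(pyrrolidin-1-yl)propyl)sulfanyl on an aromatic carbon. Going by the values given here, no measured pair includes a pentyl group, so no step tells directly what this exchange does. What the measured steps do show is that the (3-(pyrrolidin-1-yl)propyl)sulfanyl group in compound 3 gave the highest number of the three, and that each of the other groups tried at that position, azepan-1-yl in compound 1 and 4-ethylpiperidin-1-yl in compound 2, gave a lower number. Only these three compounds support that observation, and a pentyl group shares neither a ring nor an acceptor with any of them, so the direction is a guess. Because the pattern behind a 19-fold higher number from compound 1 to compound 3 (1.28 log units; beyond the scatter) and a 170-fold higher number from compound 2 to compound 3 (2.23 log units; beyond the scatter) is that removing the (3-(pyrrolidin-1-yl)propyl)sulfanyl group lowered the number, a lower number is expected for compound 4 as well, but by an uncertain amount. Compound 4 is expected to give about 3 nM in this assay, within a range from 0.5 nM to 30 nM. This expected change amounts to a 5.7-fold lower number from compound 3 to compound 4 (0.76 log units; beyond the scatter).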

Compound 4, inhibition constant: 1.9 nM
Compound 4: the middle estimate sits 1.6-fold (0.20 log units) above what was measured; the measured number falls inside the stated range.
By their numbers in this assay, from the lowest: compound 2; then compound 1; then compound 4; then compound 3.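

In this assay, a plain pentyl chain, with no ring and no hydrogen-bond acceptor, is enough at this aromatic carbon to give a lower number than the larger (3-(pyrrolidin-1-yl)propyl)sulfanyl group (a 9.0-fold lower number from compound 3 to compound 4 (0.95 log units; beyond the scatter)). The earlier compounds shown here all joined this carbon to a nitrogen or a sulfur, whereas compound 4 joins it to a carbon and still stays close to the azepan-1-yl compound, though the gap is beyond the scatter (a 2.1-fold higher number from compound 1 to compound 4 (0.32 log units; beyond the scatter)). The 4-ethylpiperidin-1-yl group still gives the lowest number of the four by a wide margin (a 19-fold higher number from compound 2 to compound 4 (1.28 log units; beyond the scatter)), so a simple chain does not match the best ring tried here.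

The exchange from compound 3 to compound 4 alters the sulfur, the chain and the pyrrolidine ring at once, so a propylsulfanyl group without the ring, or a pentyl chain ending in an amine, would be needed to separate their contributions, and a cyclohexyl ring would test whether carbon alone can match the 4-ethylpiperidin-1-yl result. Nothing measured here accounts for why these groups rank as they do.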